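Swapping Methyl for Fluoro on Two Related Cores

This account rests on a few compounds, and the source may have more. Where it says the series, first, only, none or still open, it means among the compounds named here.

Compound 1 `Cc1ccccc1C[C@H]1C(=O)OC[C@@H]1Cc1ccccc1` and compound 2 `O=C1OC[C@H](Cc2ccccc2)[C@H]1Cc1ccccc1F` share one core, while compound 3 `Cc1ccccc1C[C@H]1COC[C@@H]1Cc1ccc(Cl)c(Cl)c1` and the not yet measured compound 4 `Fc1ccccc1C[C@H]1COC[C@@H]1Cc1ccc(Cl)c(Cl)c1` share another; the difference between the two cores is not broken down here. In a functional assay on HL-60 cells (Homo sapiens) for cytotoxicity, read by WST assay, with a stated time of 48 h (on this read-out lower numbers stand for an effect already at smaller amounts and higher numbers for an effect only at larger amounts of compound), compound 1 gives 57000 nM, compound 2 gives 72000 nM, and compound 3 gives 21000 nM, the lowest of the three. The change from compound 1 to compound 2 is fluoro in place of methyl on an aromatic carbon, and it produced a 1.3-fold higher number from compound 1 to compound 2 (0.10 log units; within the scatter). The same change, (fluoro in place of methyl on an aromatic carbon), leads from compound 3 to compound 4. Because the earlier step of a 1.3-fold higher number from compound 1 to compound 2 (0.10 log units; within the scatter) lay within the scatter, a step of similar size is expected here, estimated as a 1.2-fold higher number from compound 3 to compound 4 (0.08 log units; within the scatter). Compound 4 is thus expected at 25000 nM, with a range from 12000 nM to 50000 nM.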

Compound 4, half-maximal effective concentration: 51000 nM
The estimate for compound 4 lay 2.0-fold (0.31 log units) below the measured number; the whole stated range lies below it.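

In this assay the change from methyl to fluoro gives a 2.4-fold higher number from compound 3 to compound 4 (0.39 log units; beyond the scatter) on the second core. The step on the first core lay within the scatter and this one lies beyond it, yet the two steps cannot be told apart: the same change on two cores in this assay, a 1.3-fold higher number (0.10 log units; within the scatter) from compound 1 to compound 2 and a 2.4-fold higher number (0.39 log units; beyond the scatter) from compound 3 to compound 4, 1.9-fold (0.28 log units) apart, within the scatter of two such steps. The change therefore carried over from one core to the other without a detectable difference, but two pairs do not show that it would do so on any further core, nor do they fix the true size of the step.

Open, as far as these compounds go, is how a chloro, a methoxy or an amine would behave in place of the methyl, ortho to a large group. Also open, from the compounds shown here alone, is whether the fluoro step would look the same on other aromatic carbons.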